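A Chloro Group and Cytotoxicity: Three Measured, One Awaited

A few compounds are considered here, and "the series" means these few. Any claim that something is new, unique, unknown or untested is made for them only; others in the source may bear on it.

Compound 1 `N#Cc1cc2c(Oc3ccccc3OCCn3ccc(=O)[nH]c3=O)cccc2[nH]1` gives 72000 nM in an ADME assay on MT2 cells (Homo sapiens) for cytotoxicity, read by MTT assay; on this read-out higher numbers stand for lower toxicity in this test and lower numbers for higher toxicity in this test. Compound 2 `N#Cc1cc2c(Oc3ccccc3OCCn3ccc(=O)[nH]c3=O)cc(Cl)cc2o1` gives > 100000 nM, which is a limit of the assay. Compound 3 `N#Cc1cc2c(Oc3ccccc3OCCn3ccc(=O)[nH]c3=O)cccc2o1` gives > 100000 nM, also a limit of the assay.

Compound 1 is thus the only one of the three with a number; the other two sit at the limit of > 100000 nM in this assay, at which 2 of the 3 values shown sit. The difference between the core of compound 1 and the core of compound 3 is not broken down here. From compound 3 to compound 2 the change is chloro in place of hydrogen on an aromatic carbon, and the step that the two limits leave unreadable from compound 3 to compound 2 cannot be read because both ends are limits.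

Compound 4 `N#Cc1cc2c(Oc3ccccc3OCCn3ccc(=O)[nH]c3=O)cc(Cl)cc2[nH]1` carries the same change made on compound 1: chloro in place of hydrogen on an aromatic carbon. Its step from compound 1 is expected to be a 1.3-fold higher number from compound 1 to compound 4 (0.10 log units; within the scatter), a small one, resting on compound 1 giving 72000 nM and on the unreadable step that the two limits leave unreadable from compound 3 to compound 2. Compound 4 is therefore expected to give about 90000 nM, with a fair chance that only a limit is reported.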

Compound 4, half-maximal cytotoxic concentration: 81000 nM
Compound 4: the middle estimate sits 1.1-fold (0.05 log units) above what was measured, and the stated range covers the measured number.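

In this assay, chloro in place of hydrogen on an aromatic carbon gives a 1.1-fold higher number from compound 1 to compound 4 (0.05 log units; within the scatter), so on the core of compound 1 this change makes no difference that can be told from scatter. The same change on the core of compound 3 cannot be read, so the two cores cannot be compared for it, because both ends of that step are limits: the limit of > 100000 nM in this assay, at which 2 of the 4 values shown sit. The result therefore describes one core only and does not show that the change behaves alike on both.

The compounds shown leave open whether another group on that aromatic carbon, such as bromo, an amine or a carboxylic acid, would also stay within the scatter of compound 1.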